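The source may report more compounds than this note shows. Statements on the series, on what has been measured and on what is new or still open speak of the compounds shown alone.

Compound 1 `CC(=O)/C(=N\c1cccc(Cl)c1)NNc1ccccc1[N+](=O)[O-]` is the compound around which this account turns. Among the measured compounds shown here, in an assay on isolated protein for binding affinity to corticotropin-releasing factor receptor 1 (Homo sapiens) (a higher number here means a weaker inhibitor, a lower number a stronger inhibitor), compound 1 gives 51 nM, the only value in the set that marks it out as a tight binder. Compound 2 `CC(=O)/C(=N\Nc1ccccc1)Nc1cccc(Cl)c1` shares the same atoms but arranges the anilino and hydrazino portions differently, and in this assay compound 2 gives 2720 nM; 2720 nM (2 entries), so of the two measured compounds it is compound 1 that binds far more tightly. Compound 3 `CC(=O)/C(=N\c1cccc(Cl)c1)NNc1ccccc1S(C)(=O)=O` has not yet been measured. It differs from compound 1 in one place: methylsulfonyl in place of nitro on an aromatic carbon. For the measured compounds named here, no measured pair in this set isolates such an exchange, so there is no directly comparable step. The expectation is that the change from compound 1 to compound 3 costs some affinity, a step of a 2.9-fold higher number from compound 1 to compound 3 (0.47 log units; beyond the scatter) that may reach beyond the usual scatter but is not expected to be dramatic. Compound 3 is therefore estimated at 150 nM, within a range from 40 nM to 600 nM.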

Compound 3, inhibition constant: > 10000 nM
Compound 3: only a limit was reported (the forecaster's own chance of this, stated with the estimate: 5%); at least 66-fold (1.82 log units) between middle value and limit.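

Among the compounds shown here, until now, no measured pair in this set isolated a change at this aromatic carbon, ortho to a large group; this pair shows that the position does not tolerate every replacement of nitro. Replacing nitro with methylsulfonyl leaves the number of hydrogen-bond acceptors the same, yet in this assay it gives an at least 190-fold higher number from compound 1 to compound 3 (2.29 log units; beyond the scatter), so that count alone does not preserve binding here. For compound 3, > 10000 nM is a limit of this assay and not a number: the limit of > 10000 nM in this assay, at which 1 of the 3 values shown sits.

On these data alone, whether an amine, a nitrile or a carboxylic acid at this place would retain the binding of compound 1 remains open. Also open, as far as these compounds go, is whether the same exchange would have a similar effect on the core of compound 2.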